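A few compounds are considered here, and "the series" means these few. Any claim that something is new, unique, unknown or untested is made for them only; others in the source may bear on it.

Series notes, step from compound 3 to compound 4.

Compound 3 `O=S(=O)(c1cccc(F)c1)c1ccc2c(c1)CCC[C@H]2CN1CCCS1(=O)=O` stands highest of the three numbers measured in an assay on isolated protein for displacement of a labelled ligand from 5-hydroxytryptamine receptor 6 (Homo sapiens); a lower number here means a stronger inhibitor, a higher number a weaker inhibitor: compound 3 gives 31.6 nM. The nearest is compound 2 `Cn1ccc(S(=O)(=O)c2ccc3c(c2)CCC[C@H]3CN)c1`, which in this assay gives 7.94 nM; the furthest is compound 1 `NC[C@@H]1CCCc2cc(S(=O)(=O)c3cccc(O)c3)ccc21`, which in this assay gives 0.251 nM. Going by the values given here, the one single-point step recorded, a 32-fold higher number from compound 1 to compound 2 (1.50 log units; beyond the scatter), concerns the group on the sulfonyl sulfur and not the aminomethyl position, so it does not bear on the present change.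

Compound 4 `NCC(=O)NC[C@@H]1CCCc2cc(S(=O)(=O)c3cccc(F)c3)ccc21` differs from compound 3 as follows: a group of 5 heavy atoms (2 carbon, 2 nitrogen, 1 oxygen; no ring) in place of a group of 7 heavy atoms (3 carbon, 1 nitrogen, 2 oxygen, 1 sulfur; one five-membered non-aromatic ring with 2 hetero atoms), on a saturated chain carbon bound to a saturated ring carbon. Compound 1 and compound 3 carry different groups both at the sulfonyl sulfur and on the saturated chain carbon, so their values show only that a large gap exists, not where it comes from. Among the compounds with values here, no measured step covers the exchange of the five-membered ring for the ((aminomethyl)carbonyl)amino group, so the direction is uncertain; a modest move toward lower numbers is expected, a 1.6-fold lower number from compound 3 to compound 4 (0.20 log units; within the scatter). For compound 4 the estimated value in this assay is 20 nM, within 5 nM to 80 nM.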

Compound 4, inhibition constant: 0.316 nM
Compound 4: middle estimate off by 63-fold (1.80 log units), on the high side; the whole stated range lies above it.
By their numbers in this assay, from the lowest: compounds 1 and 4 (each within the scatter of the next); then compound 2; then compound 3.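

In this assay, going by these compounds alone, replacing the five-membered ring with the ((aminomethyl)carbonyl)amino group gives a 100-fold lower number from compound 3 to compound 4 (2.00 log units; beyond the scatter), the first measured step on the saturated chain carbon bound to a saturated ring carbon, and a large one, with the rest of the molecule unchanged. The earlier step concerned only the group on the sulfonyl sulfur, so this position is now shown to matter strongly as well. No measurement shown accounts for the size of this step.

The exchange removes the ring and introduces hydrogen-bond donors in one move, so the compounds shown do not separate these differences. A plain amine at this place, an acetyl amide without the terminal amine, or a longer chain ending in an amine, each with the same sulfonyl group, would help to separate them.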